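The source may report more compounds than this note shows. Statements on the series, on what has been measured and on what is new or still open speak of the compounds shown alone.

Of the compounds shown here, two that share one core have been measured in an ADME assay on RAW264.7 cells (Mus musculus) for cytotoxicity, read by MTT assay, with a stated time of 72 h, tested at 50 uM; a higher number here means more inhibition at the concentration tested (going by the name of the read-out), a lower number less inhibition. Compound 1 `CCOC(=O)c1sc(-c2ccccn2)nc1N1CCC(NCc2ccccc2)CC1` gives 14.6%. Compound 2 `CCOC(=O)c1sc(-c2ccncc2)nc1N1CCC(NCc2ccccc2)CC1`, which carries pyridin-4-yl in place of pyridin-2-yl on an aromatic carbon, gives 10.8%. The step of a number 3.8 percentage points lower from compound 1 to compound 2 (within the scatter) is the only measured one, and on the numbers shown compound 2 stands lowest of the two, with compound 1 nearest and within the scatter of it, so no real order between them can be read. Compound 3 `CCOC(=O)c1sc(-c2ccncc2)nc1N1CCC(NCc2ccc(OCc3ccccc3)cc2)CC1` has not yet been measured; it differs from compound 2 by benzyloxy in place of hydrogen on an aromatic carbon. Going by the values given here, no measured step touches this kind of change: the single step of a number 3.8 percentage points lower from compound 1 to compound 2 (within the scatter) concerns a different change and stayed within the scatter, so it gives no guide to the size or direction here. For compound 3 the expected value is 18%, with a range from 0% to 40%. The step of a number 7.2 percentage points higher from compound 2 to compound 3 (within the scatter) that this estimate implies is expected to be modest.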

Compound 3, a percentage reported as inhibition, at one concentration (the size of the read-out at that concentration, not a potency): 8.04%
Estimate against measurement, compound 3: 10 percentage points above, and the stated range covers the measured number.
By their numbers in this assay, from the lowest: compounds 3, 2 and 1 (each within the scatter of the next).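

Benzyloxy in place of hydrogen on an aromatic carbon, para to a large group, brings 8 heavy atoms and a further six-membered aromatic ring, yet in this assay the result is a number 2.8 percentage points lower from compound 2 to compound 3 (within the scatter). Going by these compounds alone, this is the first measured change on this ring, and it shows that even a group of this size at this position does not move the reading beyond the usual scatter at the single concentration tested. Nothing available explains this result.

On these data alone, whether an amine or a carboxylic acid at the same position would give a number beyond the scatter remains open. Also open, as far as these compounds go, is whether benzyloxy would read the same alongside the pyridin-2-yl group of compound 1.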